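Thiosemicarbazone series: aryl to benzyl on the thiourea nitrogen

A few compounds are considered here, and "the series" means these few. Any claim that something is new, unique, unknown or untested is made for them only; others in the source may bear on it.

Compound 1 `Cc1ccccc1NC(=S)N/N=C/c1ccc2ccccc2n1` sits at the limit of a functional assay on SGC-7901 cells (Homo sapiens) for antiproliferative activity, read by sulforhodamine B assay, with a stated time of 72 h (on this read-out higher numbers stand for weaker inhibition and lower numbers for stronger inhibition), giving only > 100000 nM. That limit is shared by compound 3 `Cc1csc2sc(/C=N/NC(N)=S)c(C)c12`, which in this assay also returns only > 100000 nM, so the limit of > 100000 nM in this assay, at which 2 of the 3 values shown sit, marks where compound 1 stands among the three values shown. Compound 2 `CN(C)C(=S)N/N=C/c1cnc2ccccc2n1`, with a different core and a dimethyl-substituted thiourea nitrogen, gives 170 nM in this assay. Compound 4 `S=C(NCc1ccccc1)N/N=C/c1ccc2ccccc2n1` is not yet measured; it differs from compound 1 by benzyl in place of 2-methylphenyl on an amide-type nitrogen. Among the compounds with values here, no measured step in this assay shows what this change does. Compound 4 is expected to improve on compound 1 by an at least 2.5-fold lower number from compound 1 to compound 4 (0.39 log units; beyond the scatter), but the estimate is 40000 nM (3000 nM to 200000 nM), with a fair chance that only a limit is again reported.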

Compound 4, half-maximal inhibitory concentration: 53700 nM
Estimate against measurement, compound 4: 1.3-fold (0.13 log units) below; low and high end bracket the measured number.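

In this assay, within the data shown here, benzyl in place of 2-methylphenyl on the amide-type nitrogen gives the first readable step at this position: an at least 1.8-fold lower number from compound 1 to compound 4 (0.27 log units; that floor lies within the scatter). Compound 4 gives a measured number on this core, 53700 nM. As far as these compounds go, the step is only a floor, so its true size is unknown. The value for compound 1 remains a limit: the limit of > 100000 nM in this assay, at which 2 of the 4 values shown sit.

From the compounds shown here alone, the true size of this step stays open. So does what a longer chain such as phenethyl, or a cyclic amine such as morpholine, would do at this nitrogen on the core of compound 1.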